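A few compounds are considered here, and "the series" means these few. Any claim that something is new, unique, unknown or untested is made for them only; others in the source may bear on it.

The series shares one core, seen in compound 1 `CCCC(=O)Nc1ccc(S(=O)(=O)Oc2ccccc2I)cc1` and compound 2 `CC(C)(C)C(=O)Nc1ccc(S(=O)(=O)Oc2ccccc2I)cc1`, which differ only in the group on the carbonyl carbon of the amide. In a functional assay on HT-1080 cells (Homo sapiens) for antiproliferative activity, read by sulforhodamine B assay, with a stated time of 48 h (a lower number here means a stronger inhibitor, a higher number a weaker inhibitor), compound 1 gives 2000 nM, and in this assay compound 2 gives 2600 nM. Among the compounds with values here, the single measured step, a 1.3-fold higher number from compound 1 to compound 2 (0.11 log units; within the scatter), exchanges one alkyl group for another at that carbonyl carbon. Within the data shown here, on the numbers so far, compound 2 holds the highest of the two values, and its nearest neighbour, compound 1, sits within the scatter of it, so no order between them can be claimed.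

Compound 3 `O=C(CCCl)Nc1ccc(S(=O)(=O)Oc2ccccc2I)cc1` is the next member. Its difference from compound 2 is 2-chloroethyl in place of tert-butyl on a carbonyl carbon. Among the measured compounds shown here, the only step that bears on it is a 1.3-fold higher number from compound 1 to compound 2 (0.11 log units; within the scatter), which likewise swapped one saturated group for another on the same carbonyl carbon and stayed within the scatter. For the measured compounds named here, a change of this kind is therefore expected to produce no step in this assay beyond the scatter. For compound 3 the expected step is a 1.1-fold lower number from compound 2 to compound 3 (0.05 log units; within the scatter). Compound 3 is accordingly estimated at 2300 nM in this assay, with a range from 1000 nM to 5500 nM.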

Compound 3, half-maximal inhibitory concentration: 4200 nM
For compound 3 the middle estimate is 1.8-fold (0.26 log units) below the measured one, and the stated range covers the measured number.
By their numbers in this assay, from the lowest: compounds 1, 2 and 3 (each within the scatter of the next, the first and the last beyond it).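

In this assay, putting 2-chloroethyl in place of tert-butyl on the carbonyl carbon gives a 1.6-fold higher number from compound 2 to compound 3 (0.21 log units; within the scatter) and so does not separate these two groups. Within the data shown here, the closer comparison, chloro in place of methyl on a saturated chain carbon, two bonds along the chain from a carbonyl carbon, gives a 2.1-fold higher number from compound 1 to compound 3 (0.32 log units; beyond the scatter) as the first step to pass beyond the scatter, although only modestly, whereas the exchange of propyl for tert-butyl stayed within it. The compounds therefore show that a change at the chain end can move the number in the weaker direction, but nothing available explains this step.

As far as these compounds go, it remains open whether this step is specific to chloro or would also appear with fluoro, hydroxyl or an amine on that chain carbon. From the compounds shown here alone, the standing of a longer chain, a cyclopropyl group or a phenyl ring on the carbonyl carbon in this assay is also open.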